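This account rests on a few compounds, and the source may have more. Where it says the series, first, only, none or still open, it means among the compounds named here.

Compounds measured so far:
compound 1, `COc1ccc(N(CC(=O)NCCC[Te]c2ccccc2)C(=O)c2ccccc2)cc1`, 5000 nM;
compound 2, `CC(C)(C)OC(=O)NCC(=O)OCC(=O)NCCC[Te]c1ccccc1`, 10000 nM;
compound 3, `COc1ccc(N(CC(=O)NCCCSc2ccccc2)C(=O)CCSC2=C(C)C(=O)c3ccccc3C2=O)cc1`, 17000 nM.

All three were measured in a functional assay on A-431 cells (Homo sapiens) for cytotoxicity, read by MTT assay, with a stated time of 24 h; on this read-out lower numbers stand for stronger inhibition and higher numbers for weaker inhibition. Compound 1 has the lowest number of the three; compound 2 lies within the scatter of it, while compound 3 lies beyond the scatter with a higher number. The step to be followed leads from compound 1 to compound 4, `COc1ccc(N(CC(=O)NCCC[Se]c2ccccc2)C(=O)c2ccccc2)cc1`, not yet measured in this assay. The change is a group of 7 heavy atoms (6 carbon, 1 selenium; one six-membered aromatic ring of carbon only) in place of a group of 7 heavy atoms (6 carbon, 1 tellurium; one six-membered aromatic ring of carbon only), on a saturated chain carbon, three bonds along the chain from an amide-type nitrogen. Given the scatter seen among compounds 1 and 2, a modest weakening is expected, roughly a step of a 2.4-fold higher number from compound 1 to compound 4 (0.38 log units; beyond the scatter). Compound 4 is therefore estimated at 12000 nM, within a range of 4000 nM to 40000 nM.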

Compound 4, half-maximal inhibitory concentration: >= 100000 nM
Compound 4: only a limit was reported (the forecaster's own chance of this, stated with the estimate: 15%); at least 8.3-fold (0.92 log units) between middle value and limit.
By their numbers in this assay, from the lowest: compounds 1, 2 and 3 (each within the scatter of the next, the first and the last beyond it). At a limit, above all of these: compound 4.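

In this assay, within the data shown here, selenium in place of tellurium in the group on this saturated chain carbon gives an at least 20-fold higher number from compound 1 to compound 4 (1.30 log units; beyond the scatter), the first comparison here of compounds differing in one place. Compound 4 reached only a limit of the assay, >= 100000 nM. The two groups match in their counted features and differ in that one element, so this position proves sensitive to it, and the step's size rests on a limit: the limit of >= 100000 nM in this assay, at which 1 of the 4 values shown sits.

On these data alone, how far compound 4 lies past its limit stays open. Also open, as far as these compounds go, is how the shared core would fare with the matching sulfur group or with an amine at this place.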